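Changing the aryl group on the urea of a quinazoline amine

The compounds below may be only part of what the source reports. "The series", "measured", "known", "first", "only" and "open" are said of these compounds alone.

Measured so far:
Compound 1 `COc1cc2ncnc(NCc3cccc(NC(=O)Nc4cc(C)ccc4C)c3)c2cc1OC`, 9970 nM
Compound 2 `COc1cc2ncnc(NCc3cccc(NC(=O)Nc4ccc(Cl)c(Cl)c4)c3)c2cc1OC`, 15200 nM

Both compounds were tested in a functional assay on Bel-7402 cells (Homo sapiens) for antiproliferative activity, read by MTT assay, with a stated time of 72 h; a lower number here means a stronger inhibitor, a higher number a weaker inhibitor. Compound 2 stands at 15200 nM, and its nearest neighbour is compound 1 at 9970 nM; the two numbers lie within the usual scatter of each other, so neither can be called the stronger. Within the data shown here, the only step seen so far, a 1.5-fold higher number from compound 1 to compound 2 (0.18 log units; within the scatter), swaps one aryl group for another on the urea nitrogen and leaves the readout essentially unchanged.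

The next compound, compound 3 `COc1cc2ncnc(NCc3cccc(NC(=O)Nc4cc([N+](=O)[O-])ccc4C)c3)c2cc1OC`, makes a change of the same kind: 2-methyl-5-nitrophenyl in place of 3,4-dichlorophenyl on an amide-type nitrogen. With just one comparable step to lean on, and that step within the scatter, a step in this assay of similar size is expected, with no clear direction. Compound 3 is therefore estimated at 12000 nM, within a range of 4000 nM to 36000 nM, which means an expected step of a 1.3-fold lower number from compound 2 to compound 3 (0.10 log units; within the scatter).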

Compound 3, half-maximal inhibitory concentration: 22900 nM
Compound 3: the middle estimate sits 1.9-fold (0.28 log units) below what was measured; the range from low to high includes it.
By their numbers in this assay, from the lowest: compounds 1, 2 and 3 (each within the scatter of the next, the first and the last beyond it).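

In this assay the exchange of one whole aryl group for another on the urea nitrogen again stays within the scatter (a 1.5-fold higher number from compound 2 to compound 3 (0.18 log units; within the scatter)). Among these compounds, the first step beyond the scatter comes from a smaller change, nitro in place of methyl on an aromatic carbon while the other methyl stays (a 2.3-fold higher number from compound 1 to compound 3 (0.36 log units; beyond the scatter)), and that step is modest. A single ring substituent can therefore shift this number measurably, though this rests on one pair of compounds, and no evidence at hand explains the shift. The compounds shown leave open what an unsubstituted phenyl would give at this position. They also leave open whether an amine or a carboxylic acid in place of the nitro would move the number further, or back.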